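Swapping the dichlorophenoxy arm of compound 1 for a fluorophenyl sulfide

A few compounds are considered here, and "the series" means these few. Any claim that something is new, unique, unknown or untested is made for them only; others in the source may bear on it.

Measured compounds:
compound 1, `Nc1cc(N)c2nc(-c3ccccc3)c(Oc3ccc(Cl)c(Cl)c3)nc2c1`: 3550 nM
compound 2, `Nc1cc(N)c2nc(-c3ccccc3)c(NCc3ccc(Cl)c(Cl)c3)nc2c1`: 3090 nM
compound 3, `CCOC(=O)[C@H](CCC(=O)O)NC(=O)c1ccc(Sc2nc3cc(N)cc(N)c3nc2-c2ccccc2)cc1`: > 10 nM

Of the compounds shown here, three sharing one core have been tested in a functional assay on K562 cells (Homo sapiens) for inhibition, read by sulforhodamine B assay, with a stated time of 48 h; on this read-out lower numbers stand for stronger inhibition of growth and higher numbers for weaker inhibition of growth. Compound 1, `Nc1cc(N)c2nc(-c3ccccc3)c(Oc3ccc(Cl)c(Cl)c3)nc2c1`, gives 3550 nM in this assay. Compound 2, `Nc1cc(N)c2nc(-c3ccccc3)c(NCc3ccc(Cl)c(Cl)c3)nc2c1`, gives 3090 nM, and its number and that of compound 1 lie within the scatter of each other, so neither can be called the more potent. Compound 3, `CCOC(=O)[C@H](CCC(=O)O)NC(=O)c1ccc(Sc2nc3cc(N)cc(N)c3nc2-c2ccccc2)cc1`, is reported only as a limit of the assay, > 10 nM, and not as a number; this is the one limit among the three values (the limit of > 10 nM in this assay, at which 1 of the 3 values shown sits).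

The compound still to be measured is compound 4, `Nc1cc(N)c2nc(-c3ccccc3)c(Sc3ccc(F)cc3)nc2c1`. It differs from compound 1 in one place: (4-fluorophenyl)sulfanyl in place of 3,4-dichlorophenoxy on an aromatic carbon. For the measured compounds named here, since no pair of measured compounds differs in only one place, no measured step shows what such a swap does here. The expectation for this assay is a step of modest size, if any, with a direction that cannot be fixed from the compounds shown; the estimated step from compound 1 to compound 4 is a 1.1-fold higher number from compound 1 to compound 4 (0.05 log units; within the scatter).

Compound 4 is therefore estimated to give 4000 nM in this assay, expected to fall between 1300 nM and 12000 nM.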

Compound 4, concentration for 50% growth inhibition: 39800 nM
For compound 4 the middle estimate is 10-fold (1.00 log units) below the measured one, and the stated range ends below it.
By their numbers in this assay, from the lowest: compounds 2 and 1 (each within the scatter of the next); then compound 4.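

In this assay, for the compounds shown here, replacing 3,4-dichlorophenoxy with (4-fluorophenyl)sulfanyl gives an 11-fold higher number from compound 1 to compound 4 (1.05 log units; beyond the scatter), which means weaker inhibition of growth and is the only measured step showing that this aromatic carbon is sensitive to the arm it carries. The loss appears even though both arms hold one six-membered aromatic ring of carbon only, carry no net charge and have matching counts of hydrogen-bond donors and acceptors, so these shared features do not make the two arms interchangeable here. Nothing measured among these compounds gives a reason for this loss.

The swap changes the atom joining the ring to the core and the halogens on that ring together, so this single step cannot show which change matters, or whether both do. A (3,4-dichlorophenyl)sulfanyl arm or a 4-fluorophenoxy arm at this carbon would pull the two changes apart, and a comparison of either with compound 1 and compound 4 would show how much of the step belongs to the sulfur and how much to the halogens.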